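The source may report more compounds than this note shows. Statements on the series, on what has been measured and on what is new or still open speak of the compounds shown alone.

In a functional assay on cells (Homo sapiens) for cytotoxicity, read by MTT assay, with a stated time of 24 h; a lower number here means a stronger inhibitor, a higher number a weaker inhibitor:

- compound 1 `CCCCCCCCCCCCCCNC(=O)[C@H](CO)/N=C/c1ccccc1OC`: 12500 nM
- compound 2 `CCCCCCCCCCCCCCNC(=O)[C@H](CO)NCc1ccccc1O`: 75300 nM
- compound 3 `CCCCCCCCCCCCCCNC(=O)[C@H](CO)/N=C/c1ccccc1O`: 19000 nM

Compound 3 is level with compound 1 within the scatter, and the gap to compound 2 is clear: a 4.0-fold lower number from compound 2 to compound 3 (0.60 log units; beyond the scatter).

Compound 4 `CCCCCCCCCCCCCCNC(=O)[C@H](CO)/N=C/c1ccccc1` carries hydrogen in place of hydroxy on an aromatic carbon. The closest measured change is at the same oxygen: a 1.5-fold higher number from compound 1 to compound 3 (0.18 log units; within the scatter). The larger steps, a 6.0-fold higher number from compound 1 to compound 2 (0.78 log units; beyond the scatter) and a 4.0-fold lower number from compound 2 to compound 3 (0.60 log units; beyond the scatter), leave the hydroxy or its methyl cap untouched and bear less. Among the measured compounds shown here, no measured pair removes the oxygen outright, so uncertainty remains.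

In this assay, the expected step is none beyond the scatter: a 1.1-fold lower number from compound 3 to compound 4 (0.05 log units; within the scatter). Compound 4 is estimated at 17000 nM, within an expected range of 7000 nM to 40000 nM.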

Compound 4, half-maximal inhibitory concentration: 7670 nM
For compound 4 the middle estimate is 2.2-fold (0.35 log units) above the measured one; the range from low to high includes it.
By their numbers in this assay, from the lowest: compounds 4, 1 and 3 (each within the scatter of the next, the first and the last beyond it); then compound 2.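

In this assay, among the compounds shown here, the 2-hydroxyphenyl to phenyl change is the first single change at this aromatic carbon to go beyond the scatter (a 2.5-fold lower number from compound 3 to compound 4 (0.39 log units; beyond the scatter)), while hydrogen in place of methoxy stays within it (a 1.6-fold lower number from compound 1 to compound 4 (0.21 log units; within the scatter)). The larger step (a 9.8-fold lower number from compound 2 to compound 4 (0.99 log units; beyond the scatter)) also alters the link to the ring, so it cannot be assigned to this carbon alone. Nothing available explains these steps.

From the compounds shown here alone, whether fluorine or an amine at this carbon would match hydrogen remains open. So does whether a longer chain would change these steps.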